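Swapping methyl for methoxy on a weak compound

The source may hold more compounds than are shown below. What is called first, only, known or untested is meant among the compounds shown, and "the series" means these compounds.

In a functional assay on HT-29 cells (Homo sapiens) for antiproliferative activity, read by sulforhodamine B assay, with a stated time of 48 h (a higher number here means a weaker inhibitor, a lower number a stronger inhibitor), compound 1 (`Cc1ccccc1OS(=O)(=O)c1ccc(N2CCN(C)C2=O)cc1`) gives 4800 nM. Compound 2 (`Cc1ccc(OS(=O)(=O)c2ccc(N3CCN(C)C3=O)cc2)cc1`) stands at > 100000 nM, which is a limit and not a number. Going by the values given here, the one measured step, an at least 20-fold higher number from compound 1 to compound 2 (1.31 log units; beyond the scatter), came with 4-methylphenyl in place of 2-methylphenyl on an oxygen. Compound 3 (`COc1ccc(OS(=O)(=O)c2ccc(N3CCN(C)C3=O)cc2)cc1`) instead has methoxy in place of methyl on an aromatic carbon, para to a large group: methoxy in place of methyl on an aromatic carbon. It keeps its group where compound 2 has one, so it is expected to stay on the weak side of that step. The expected step, none clearly beyond the scatter, is a number no higher from compound 2 to compound 3 (the limit leaves the size open). For compound 3 the estimate is 100000 nM, within an expected range of 30000 nM to 200000 nM.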

Compound 3, half-maximal inhibitory concentration: > 100000 nM
Compound 3: no number, only a limit; the forecaster's own chance of this, stated with the estimate: 65%; the middle value lies on the limit itself.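

In this assay, compound 3 also gives a limit and not a number: > 100000 nM. Like methyl, methoxy at this place, para to a large group, stays on the weak side, with an at least 20-fold higher number from compound 1 to compound 3 (1.31 log units; beyond the scatter). The two limits leave the step from compound 2 to compound 3 unreadable: the limit of > 100000 nM in this assay, at which 2 of the 3 values shown sit.

As far as these compounds go, the true values of compound 2 and compound 3 beyond that limit stay open. So does whether an amine or a carboxylic acid in place of the methoxy would bring back a measurable number.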